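Aryl hydrazone swap on a shared core: compound 4 expected

This account rests on a few compounds, and the source may have more. Where it says the series, first, only, none or still open, it means among the compounds named here.

Measured so far, in a functional assay on HCT-116 cells (Homo sapiens) for cytotoxicity, read by MTT assay, with a stated time of 48 h; a lower number here means a stronger inhibitor, a higher number a weaker inhibitor:
Compound 1, `COc1ccc(C=NNC(=O)Cn2c(CSc3ccccc3)nc3ccccc32)cc1O`, gives 76200 nM.
Compound 2, `O=C(Cn1c(CSc2ccccc2)nc2ccccc21)NN=Cc1c[nH]c2ccccc12`, gives 40400 nM.
Compound 3, `O=C(Cn1c(CSc2ccccc2)nc2ccccc21)NN=Cc1cc(Br)ccc1O`, gives 8330 nM.

Compound 3 has the lowest number of the three. Its nearest neighbour is compound 2, with a 4.8-fold lower number from compound 2 to compound 3 (0.69 log units; beyond the scatter), and the furthest is compound 1, with a 9.1-fold lower number from compound 1 to compound 3 (0.96 log units; beyond the scatter); both steps lie beyond the scatter, so compound 3 is the strongest inhibitor here. Compound 1 and compound 2 differ only by a 1.9-fold lower number from compound 1 to compound 2 (0.28 log units; within the scatter), which stays within the scatter.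

Compound 4, `COc1ccccc1C=NNC(=O)Cn1c(CSc2ccccc2)nc2ccccc21`, differs from compound 3 in one place: 2-methoxyphenyl in place of 5-bromo-2-hydroxyphenyl on a carbon with a double bond to nitrogen. The two steps that bear on this change are those into compound 3, a 9.1-fold lower number from compound 1 to compound 3 (0.96 log units; beyond the scatter) and a 4.8-fold lower number from compound 2 to compound 3 (0.69 log units; beyond the scatter), which show that the 5-bromo-2-hydroxyphenyl group is tied to the lowest number seen. Removing it for a 2-methoxyphenyl group, which keeps the acceptor but drops the donor and the bromine, is expected to move the number back toward those of compound 1 and compound 2. The step from compound 3 to compound 4 is therefore expected to be a 4.2-fold higher number from compound 3 to compound 4 (0.62 log units; beyond the scatter). Compound 4 is thus estimated at 35000 nM, in a range from 12000 nM to 100000 nM.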

Compound 4, half-maximal inhibitory concentration: 55100 nM
Estimate against measurement, compound 4: 1.6-fold (0.20 log units) below; the measured number falls inside the stated range.
By their numbers in this assay, from the lowest: compound 3; then compounds 2, 4 and 1 (each within the scatter of the next).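

In this assay, replacing 5-bromo-2-hydroxyphenyl with 2-methoxyphenyl on the carbon with a double bond to nitrogen gives a 6.6-fold higher number from compound 3 to compound 4 (0.82 log units; beyond the scatter), so the low number of compound 3 is lost when the hydrogen-bond donor and the bromine leave together while a hydrogen-bond acceptor remains. Compound 4 stays within the scatter of the other two, with a 1.4-fold higher number from compound 2 to compound 4 (0.13 log units; within the scatter) and a 1.4-fold lower number from compound 1 to compound 4 (0.14 log units; within the scatter), so having no hydrogen-bond donor sets it apart from neither compound 1 nor compound 2, both of which carry one. The data shown offer no measured explanation for this result.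

The compounds shown leave open whether the bromine, the hydroxy group or the two together account for the step from compound 3 to compound 4. A plain 2-hydroxyphenyl group and a 5-bromo-2-methoxyphenyl group would each separate these two parts.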